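Aryl swap on the pyrimidine arm: compound 2 to compound 3

The compounds below may be only part of what the source reports. "The series", "measured", "known", "first", "only" and "open" are said of these compounds alone.

Measured so far:
- compound 1, `Cn1cc(/C=C2/C(=O)Nc3ccccc32)c2cc(Nc3nccc(-c4ccc(O)cc4)n3)ccc21`, a functional assay on U-87MG ATCC cells (Homo sapiens) for cytotoxicity, read by MTT assay, with a stated time of 48 h; a lower number here means a stronger inhibitor, a higher number a weaker inhibitor: 13200 nM
- compound 2, `Cn1cc(/C=C2/C(=O)Nc3ccccc32)c2cc(Nc3nccc(-c4ccc(C(F)(F)F)cc4)n3)ccc21`, this assay: 26000 nM

Within the data shown here, compound 2 carries the highest number of the two measured; its nearest neighbour is compound 1, and the step of a 2.0-fold higher number from compound 1 to compound 2 (0.29 log units; within the scatter), the only measured step in the set, is the change of trifluoromethyl in place of hydroxy on an aromatic carbon. Both compounds sit at weak inhibition in this assay.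

Compound 3, `Cn1cc(/C=C2/C(=O)Nc3ccccc32)c2cc(Nc3nccc(-c4ccc(Cl)cc4Cl)n3)ccc21`, is not yet measured. It differs from compound 2 in one place: 2,4-dichlorophenyl in place of 4-(trifluoromethyl)phenyl on an aromatic carbon. Among the measured compounds shown here, the one measured step bears on the same aromatic carbon of the shared core, and it stayed within the scatter, so the two aryl groups tested so far gave numbers of similar size. For the measured compounds named here, no step in the set speaks to a dichlorophenyl group, so the expectation rests on that one step alone.

Compound 3 is therefore expected to stay near compound 2, with a step of a 1.0-fold lower number from compound 2 to compound 3 (0.02 log units; within the scatter) that need not exceed the scatter in either direction. The estimate for compound 3 in this assay is 25000 nM, with a range from 8000 nM to 80000 nM.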

Compound 3, half-maximal inhibitory concentration: 36800 nM
Compound 3: middle estimate off by 1.5-fold (0.17 log units), on the low side, within the range that was stated.
By their numbers in this assay, from the lowest: compounds 1, 2 and 3 (each within the scatter of the next, the first and the last beyond it).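

On this aromatic carbon of the shared core, read in this assay, 2,4-dichlorophenyl in place of 4-(trifluoromethyl)phenyl gives a step within the scatter (a 1.4-fold higher number from compound 2 to compound 3 (0.15 log units; within the scatter)), so a phenyl ring with two chlorine atoms and none of the fluorine atoms of trifluoromethyl reads the same as compound 2 at this level of resolution. The set now holds its first step beyond the scatter (a 2.8-fold higher number from compound 1 to compound 3 (0.45 log units; beyond the scatter)), modest in size, for 2,4-dichlorophenyl in place of 4-hydroxyphenyl; compound 2 lies within the scatter of both compound 1 and compound 3, so this one pair is the only firm separation among the three aryl groups. Nothing on record explains the separation between that pair.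

On these data alone, all three aryl groups are phenyl rings bearing only hydroxy, trifluoromethyl or chlorine, so the response at this position to an amine such as morpholine or piperazine, a carboxylic acid, or a pyridine ring in place of phenyl remains open. As far as these compounds go, whether any change at this carbon can move the numbers far from the weak range seen so far also remains open.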